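A few compounds are considered here, and "the series" means these few. Any claim that something is new, unique, unknown or untested is made for them only; others in the source may bear on it.

Measured compounds and their oral bioavailability values in an in vivo ADME assay on the whole organism for pharmacokinetics, with Rattus norvegicus as the target, at a dose of 1 mg/kg by the oral route; a lower number here means that a smaller share of the oral dose reaches the circulation, a higher number that a larger share of the oral dose reaches the circulation:
- compound 1, `CSC(=S)N1CC2(CC2)CS/C1=N\c1ccccc1C(C)C`, gives 14%
- compound 2, `CSC(=S)N1CC2(CCCC2)CS/C1=N\c1ccccc1C(C)C`, gives 8.9%
- compound 3, `COc1ccccc1/N=C1\SCC2(CCCCC2)CN1C(=S)SC`, gives 0.4%

All three share one core and differ in the size of the ring fused to it and in the group carried by the double-bonded nitrogen. Compound 3, with the largest fused ring and a 2-methoxyphenyl group, stands apart from compound 1 by a gap that lies beyond the scatter of this assay, while its gap to compound 2 stays within that scatter; so the numbers alone place compound 3 clearly under compound 1 but not clearly apart from compound 2.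

Compound 4, `COc1cccc(/N=C2\SCC3(CCCCC3)CN2C(=S)SC)c1`, keeps every atom of compound 3 and moves only the position of the methoxy group on the ring: 3-methoxyphenyl in place of 2-methoxyphenyl on a double-bonded nitrogen. Going by the values given here, no pair among the measured compounds differs in this way, so nothing here shows how such a shift acts on this assay. Going by these compounds, with the fused ring and the rest of the core unchanged, the expected step from compound 3 to compound 4 is a number 2.6 percentage points higher from compound 3 to compound 4 (within the scatter), that is, no change reaching beyond the scatter, with the range kept wide because the comparison is untested. Compound 4 is therefore estimated at 3%, between 0.2% and 20%.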

Compound 4, oral bioavailability: 13%
Compound 4: the middle estimate sits 10 percentage points below what was measured, within the range that was stated.
By their numbers in this assay, from the lowest: compounds 3, 2, 4 and 1 (each within the scatter of the next, the first and the last beyond it).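

Moving the methoxy group, with 3-methoxyphenyl in place of 2-methoxyphenyl on a double-bonded nitrogen, gives the first comparison in this set that changes one place only, and in this assay it produces a number 12.6 percentage points higher from compound 3 to compound 4 (beyond the scatter) and so a real difference. The two compounds hold the same atoms and the same counts of hydrogen-bond donors and acceptors, so those counts cannot separate them, and the place of the methoxy group on the ring matters for this read-out in this pair. No measurement at hand explains how the shift acts on the share of the oral dose that reaches the circulation.

Going by these compounds, this rests on one pair with one fused ring, so it remains open whether the same shift would give a step of similar size on a core with a smaller fused ring. Also open, on these data alone, is what the same place on the ring would tolerate if it carried something other than the methoxy group, such as an amine or a carboxylic acid.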